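From compound 3 to a larger group on the carbonyl

This account rests on a few compounds, and the source may have more. Where it says the series, first, only, none or still open, it means among the compounds named here.

In an ADME assay on microsomes from liver (Mus musculus) for metabolic stability, read by LC-MS, with a stated time of 30 min, tested at 1 uM (a lower number here means that less of the compound is left, a higher number that more of the compound is left), compound 3 (`CC[C@@H]1CC[C@@H](C(=O)N2CCN(C)[C@@H](C)C2)N1C(=O)C1=C(C(C)C)N2C(=N[C@@](C)(c3ccc(Cl)cc3)[C@H]2c2ccc(Cl)cc2)S1`) gives 69% and lies within the scatter of compound 2 (`CC[C@@H]1CC[C@@H](C(=O)N2CCN(C)[C@H](C)C2)N1C(=O)C1=C(C(C)C)N2C(=N[C@@](C)(c3ccc(Cl)cc3)[C@H]2c2ccc(Cl)cc2)S1`) at 76% while compound 1 (`CC(=O)N1CCN(C(=O)[C@@H]2CC[C@@H](C)N2C(=O)C2=C(C(C)C)N3C(=N[C@@](C)(c4ccc(Cl)cc4)[C@H]3c3ccc(Cl)cc3)S2)C[C@H]1C`) at 55% lies beyond the scatter on the lower side. Compound 4 (`CC[C@@H]1CC[C@@H](C(=O)N2CCN(C(C)=O)[C@H](C)C2)N1C(=O)C1=C(C(C)C)N2C(=N[C@@](C)(c3ccc(Cl)cc3)[C@H]2c2ccc(Cl)cc2)S1`) departs from compound 3 by a group of 10 heavy atoms (7 carbon, 2 nitrogen, 1 oxygen; one six-membered non-aromatic ring with 2 hetero atoms) in place of a group of 8 heavy atoms (6 carbon, 2 nitrogen; one six-membered non-aromatic ring with 2 hetero atoms), on a carbonyl carbon with the 3,4-dimethylpiperazin-1-yl group leaving. Going by the values given here, the only measured step is a number 7 percentage points lower from compound 2 to compound 3 (within the scatter) and it reflects the fact that compounds 2 and 3 differ only in the configuration as drawn so it does not speak directly to this exchange. Compound 1 carries a similar group in this place, differs elsewhere too, and gives 55% as the nearest guide. A small downward move within the scatter is therefore expected, namely a number 9 percentage points lower from compound 3 to compound 4 (within the scatter) as the estimated step. Compound 4 is estimated at 60% (expected range 42% to 76%).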

Compound 4, percent of the compound remaining: 59%
Estimate against measurement, compound 4: 1 percentage points above, and the stated range covers the measured number.
By their numbers in this assay, from the lowest: compounds 1, 4, 3 and 2 (each within the scatter of the next, the first and the last beyond it).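

Going by these compounds alone, on an amine nitrogen in a ring, acetyl in place of methyl gives the first step beyond the scatter: a number 17 percentage points lower from compound 2 to compound 4 (beyond the scatter). Read as an exchange on the carbonyl carbon, the same pair of groups gives a number 10 percentage points lower from compound 3 to compound 4 (within the scatter), while methyl in place of hydrogen on a saturated chain carbon bound to a saturated ring carbon gives a number 4 percentage points higher from compound 1 to compound 4 (within the scatter). The two comparators for the acetyl compound are otherwise alike: the fact that compounds 2 and 3 differ only in the configuration as drawn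

The compounds shown leave open whether this step belongs to acetyl alone or would also follow from a methanesulfonyl or methoxycarbonyl group on that nitrogen.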